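The source may hold more compounds than are shown below. What is called first, only, known or untested is meant among the compounds shown, and "the series" means these compounds.

Measured so far:
Compound 1 `CN(C(=O)c1ccccc1)c1ccc(C(O)(C(F)(F)F)C(F)(F)F)cc1`: in an ADME assay on Li23 cells (Homo sapiens) for cytotoxicity, read by WST assay (on this read-out higher numbers stand for lower toxicity in this test and lower numbers for higher toxicity in this test), compound 1 gives 65000 nM.
Compound 2 `CN(C(=O)c1ccccn1)c1ccc(C(O)(C(F)(F)F)C(F)(F)F)cc1`: compound 2 gives > 100000 nM, which is a limit of the assay (the limit of > 100000 nM in this assay, at which 1 of the 3 values shown sits).
Compound 3 `O=C(c1ccccc1)N(Cc1ccccc1)c1ccc(C(O)(C(F)(F)F)C(F)(F)F)cc1`: compound 3 gives 7500 nM.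

Compound 1 holds the highest of the two numbers shown; the nearest is compound 3, reached by an 8.7-fold lower number from compound 1 to compound 3 (0.94 log units; beyond the scatter). The step of an at least 1.5-fold higher number from compound 1 to compound 2 (0.18 log units; that floor lies within the scatter) runs onto a limit and cannot be sized further.

Compound 4 `CN(C(=O)c1ccccc1)c1ccc(C(OCCO)(C(F)(F)F)C(F)(F)F)cc1` differs from compound 1 by 2-hydroxyethyl in place of hydrogen on an oxygen on a saturated carbon. Neither measured step touches this oxygen: both alter the amide end of the shared core. The replacement on the amide nitrogen going from compound 1 to compound 3 lowered the number beyond the scatter, while the ring exchange on the carbonyl carbon going from compound 1 to compound 2 stayed within it. Going by the values given here, with no measured step bearing directly on the hydroxy, the expectation for compound 4 is a step of a 1.3-fold lower number from compound 1 to compound 4 (0.11 log units; within the scatter), not beyond the scatter. Compound 4 is therefore estimated at 50000 nM, between 20000 nM and 100000 nM.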

Compound 4, half-maximal cytotoxic concentration: > 20000 nM
Compound 4: only a limit was reported; the forecaster's own chance of this, stated with the estimate: 20%; the middle value is on the limit's open side.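

Going by these compounds alone, compound 4 gives > 20000 nM, which is a limit of the assay, and no step from compound 1 to compound 4 can be read from it. Still open, on these data alone, is whether 2-hydroxyethyl in place of hydrogen on that oxygen shifts the number beyond the scatter, in either direction, relative to compound 1.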